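This account rests on a few compounds, and the source may have more. Where it says the series, first, only, none or still open, it means among the compounds named here.

Compound 1, `O=C(Nc1cccc(-n2cc(-c3ccncc3)c(-c3ccc(Cl)c(O)c3)n2)c1)Nc1cccc(C(F)(F)F)c1`; in a functional assay on RPMI-8226 cells (Homo sapiens) for inhibition, read by sulforhodamine B assay, with a stated time of 48 h (on this read-out higher numbers stand for weaker inhibition of growth and lower numbers for stronger inhibition of growth), compound 1 gives only a limit of > 32500 nM.
Compound 2, `COc1cc(-c2nn(-c3cccc(NC(=O)c4cccc(C(F)(F)F)c4)c3)cc2-c2ccncc2)ccc1Cl`; in this assay compound 2 gives 26600 nM.
Compound 3, `O=C(Nc1cccc(-n2cc(-c3ccncc3)c(-c3ccc(Cl)c(O)c3)n2)c1)Nc1cc(C(F)(F)F)cc(C(F)(F)F)c1`; in this assay compound 3 gives only a limit of > 50000 nM.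

Within the data shown here, compound 2 thus holds the only actual number among the three; the other two values are limits. Compound 4, `COc1cc(-c2nn(-c3cccc(NC(=O)Nc4ccc(Cl)c(C(F)(F)F)c4)c3)cc2-c2ccncc2)ccc1Cl`, differs from compound 2 by (4-chloro-3-(trifluoromethyl)phenyl)amino in place of 3-(trifluoromethyl)phenyl on a carbonyl carbon. Among the measured compounds shown here, the one measured step, a step that the two limits leave unreadable from compound 1 to compound 3, concerns two limits and a different core, so its size cannot be read, and no measured step bears directly on the change from compound 2 to compound 4. Both ureas, compound 1 and compound 3, sit at limits (the limit of > 32500 nM in this assay, at which 1 of the 3 values shown sits, (the limit of > 50000 nM in this assay, at which 1 of the 3 values shown sits)), so compound 4 is expected to land near a limit as well. Compound 4 is estimated at 30000 nM, within 8000 nM to 100000 nM. For compound 4 the expected step is a 1.1-fold higher number from compound 2 to compound 4 (0.05 log units; within the scatter).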

Compound 4, concentration for total growth inhibition: 3250 nM
Estimate against measurement, compound 4: 9.2-fold (0.97 log units) above, outside the stated range (below it).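

On the carbonyl carbon, (4-chloro-3-(trifluoromethyl)phenyl)amino in place of 3-(trifluoromethyl)phenyl gives an 8.2-fold lower number from compound 2 to compound 4 (0.91 log units; beyond the scatter) in this assay, the first step among these compounds whose size can be read. The entering group brings a nitrogen, with a hydrogen-bond donor, and a chlorine in a single change. Nothing measured here accounts for the step. The compounds shown leave open how much of it belongs to the nitrogen and how much to the chlorine. They also leave open how an amine or a carboxylic acid would behave on this carbonyl carbon.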